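Amine ring contraction on the pyrimidine amide

This account rests on a few compounds, and the source may have more. Where it says the series, first, only, none or still open, it means among the compounds named here.

For the measured compounds named here, compound 1 `COc1cc2c(Oc3ccc(NC(=O)c4cc(-c5ccccc5)ccn4)cc3F)ccnc2cc1OCCCN1CCCC1` and compound 2 `COc1cc2c(Oc3ccc(NC(=O)c4nccc(-c5ccccc5)n4)cc3F)ccnc2cc1OCCCN1CCCCC1` differ in two places, so no single step connects them. In a functional assay on HT-29 cells (Homo sapiens) for cytotoxicity, read by MTT assay, with a stated time of 72 h (a lower number here means a stronger inhibitor, a higher number a weaker inhibitor), compound 1 gives 120 nM, while compound 2 gives 260 nM, the higher of the two numbers. Compound 3 `COc1cc2c(Oc3ccc(NC(=O)c4nccc(-c5ccccc5)n4)cc3F)ccnc2cc1OCCCN1CCCC1` is not yet measured; it carries pyrrolidin-1-yl in place of piperidin-1-yl on a saturated chain carbon, three bonds along the chain from an oxygen on an aromatic ring relative to compound 2. Going by the values given here, with no single-change step available, the expectation for this assay is a small downward move, not clearly beyond the scatter. The step from compound 2 to compound 3 is estimated as a 1.4-fold lower number from compound 2 to compound 3 (0.14 log units; within the scatter). Compound 3 is expected to give 190 nM, within 80 nM to 450 nM.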

Compound 3, half-maximal inhibitory concentration: 390 nM
The estimate for compound 3 lay 2.1-fold (0.31 log units) below the measured number; the range from low to high includes it.
By their numbers in this assay, from the lowest: compound 1; then compounds 2 and 3 (each within the scatter of the next).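

In this assay pyrrolidin-1-yl in place of piperidin-1-yl, on a saturated chain carbon, gives a 1.5-fold higher number from compound 2 to compound 3 (0.18 log units; within the scatter) and so leaves this amine position without a resolved ring-size preference on the pyrimidine amide. For the compounds shown here, by contrast, 4-phenylpyrimidin-2-yl in place of 4-phenylpyridin-2-yl on a carbonyl carbon gives a 3.3-fold higher number from compound 1 to compound 3 (0.51 log units; beyond the scatter) as the only single change here beyond the scatter, a modest step.

As far as these compounds go, whether morpholin-4-yl or a longer chain carrying either amine would move the number beyond the scatter remains open. No evidence at hand bears on either step.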